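Methyl-to-chloro swap on the aryl ether of compound 2

A few compounds are considered here, and "the series" means these few. Any claim that something is new, unique, unknown or untested is made for them only; others in the source may bear on it.

Compound 2 `Cc1cccc(Oc2ccc(CC3SC(=O)NC3=O)cc2)c1` gives 203 nM in a functional assay for agonist activity at Free fatty acid receptor 1 (Homo sapiens), read by FLIPR, in the presence of a further agent that is not named here; on this read-out higher numbers stand for an effect only at larger amounts of compound and lower numbers for an effect already at smaller amounts. Compound 1 `Cc1ccc(C)c(Oc2ccc(CC3SC(=O)NC3=O)cc2)c1` gives 238 nM and compound 3 `Cc1cc(C)cc(Oc2ccc(CC3SC(=O)NC3=O)cc2)c1` gives 96 nM, so compound 2 sits second highest of the three numbers. The smallest gap is a 1.2-fold lower number from compound 1 to compound 2 (0.07 log units; within the scatter); the step of a 2.1-fold lower number from compound 2 to compound 3 (0.33 log units; beyond the scatter) is larger. Compound 4 `O=C1NC(=O)C(Cc2ccc(Oc3cccc(Cl)c3)cc2)S1` differs from compound 2 by chloro in place of methyl on an aromatic carbon. Within the data shown here, no measured step exchanges methyl for chloro; the steps seen so far only add or remove a methyl and stay at or near the scatter, so nothing in the set argues for a step beyond the scatter in this assay in either direction. Compound 4 is therefore expected at about 200 nM, within 90 nM to 450 nM. This estimate corresponds to an expected 1.0-fold lower number from compound 2 to compound 4 (0.01 log units; within the scatter).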

Compound 4, half-maximal effective concentration: 318 nM
For compound 4 the middle estimate is 1.6-fold (0.20 log units) below the measured one; the range from low to high includes it.
By their numbers in this assay, from the lowest: compound 3; then compounds 2, 1 and 4 (each within the scatter of the next).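

Among these compounds, at this place, meta to a large group, 3-methylphenyl to 3-chlorophenyl is the first exchange of one substituent for another rather than the addition or removal of a methyl. In this assay it gives a 1.6-fold higher number from compound 2 to compound 4 (0.19 log units; within the scatter), so chloro is accepted in place of methyl here without a step beyond the scatter. No supporting data on this result are available.

Still open, on these data alone, is whether an amine, a methoxy group or a carboxylic acid at this place would give a step beyond the scatter. Also open, as far as these compounds go, is whether chloro would give the same result alongside the second methyl of compound 3.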